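This account rests on a few compounds, and the source may have more. Where it says the series, first, only, none or still open, it means among the compounds named here.

Measured so far in a functional assay on HepG2 cells (Homo sapiens) for inhibition, read by MTT assay, with a stated time of 72 h (a lower number here means a stronger inhibitor, a higher number a weaker inhibitor), are these three compounds.

- Compound 1 `Cc1cccc(CN2CCc3ncn(COCc4ccccc4)c3/C(=C/c3ccccc3)C2=O)c1` gives 34300 nM
- Compound 2 `O=C1/C(=C\c2ccccc2)c2c(ncn2COCc2ccccc2)CCN1Cc1ccc(-c2ccccc2)cc1` gives 72500 nM
- Compound 3 `O=C1/C(=C\c2ccccc2)c2c(ncn2COCc2ccccc2)CCN1Cc1ccc(Cl)cc1` gives 47900 nM

Compound 3 cannot be told apart from either of the others, as a 1.4-fold higher number from compound 1 to compound 3 (0.15 log units; within the scatter) and a 1.5-fold lower number from compound 2 to compound 3 (0.18 log units; within the scatter) show. Only a 2.1-fold higher number from compound 1 to compound 2 (0.33 log units; beyond the scatter) passes beyond the scatter, and that step is modest.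

Compound 4 `O=C1/C(=C\c2ccccc2)c2c(ncn2COCc2ccccc2)CCN1Cc1ccc2ccccc2c1` has not yet been measured. It carries naphthalen-2-yl in place of 4-chlorophenyl on a saturated chain carbon bound to an amide-type nitrogen in a ring and the rest of the molecule stays the same.

All three measured steps changed the group at this same place, and none of them moved the number far. The closest guide is compound 2, whose 4-phenylphenyl group also has a second aromatic ring, and there the data show a 1.5-fold lower number from compound 2 to compound 3 (0.18 log units; within the scatter) between it and its chloro partner. No step beyond the scatter is therefore expected in this assay, with only a slight lean towards a higher number. The expected change is a 1.1-fold higher number from compound 3 to compound 4 (0.06 log units; within the scatter) and rests on just three compounds. For compound 4 the estimated value is 55000 nM with an expected range from 28000 nM to 100000 nM in this assay.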

Compound 4, half-maximal inhibitory concentration: 23700 nM
For compound 4 the middle estimate is 2.3-fold (0.37 log units) above the measured one; measured number outside the range, below it.
By their numbers in this assay, from the lowest: compounds 4, 1, 3 and 2 (each within the scatter of the next, the first and the last beyond it).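

In this assay, the number of aromatic rings at this place does not settle the result: a 3.1-fold lower number from compound 2 to compound 4 (0.49 log units; beyond the scatter) shows that naphthalen-2-yl and 4-phenylphenyl, each with two aromatic rings, can be told apart, so how the two rings are arranged matters here. Among these compounds, the change from 4-chlorophenyl gives a 2.0-fold lower number from compound 3 to compound 4 (0.31 log units; beyond the scatter) and is the first step from that group to pass beyond the scatter, though it remains modest, while a 1.4-fold lower number from compound 1 to compound 4 (0.16 log units; within the scatter) means that compound 4 cannot be told apart from compound 1. The compounds shown come with no measurement that would explain these differences.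

Every group shown at this place is aromatic and, apart from the chlorine of 4-chlorophenyl, made only of carbon and hydrogen, so the effect of an amine, a carboxylic acid or a saturated ring such as cyclohexyl remains open. Also open, going by these compounds, is whether a longer chain linking naphthalen-2-yl to the amide-type nitrogen would keep the gain over compound 2 and compound 3, and whether that gain would hold with changes elsewhere on the shared core.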